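The source may hold more compounds than are shown below. What is called first, only, known or untested is meant among the compounds shown, and "the series" means these compounds.

In a functional assay on NT2 cells (Homo sapiens) for inhibition (on this read-out higher numbers stand for weaker inhibition and lower numbers for stronger inhibition), compound 1 `CC[C@@H](C(=O)N[C@@H](CC(=O)O)C(=O)CSCc1ccccc1)n1cccc(NC(=O)[C@H](CC(=O)O)NC(C)=O)c1=O` gives 5.2 nM and compound 2 `CCCCCCN(C)CNCC(=O)[C@H](CC(=O)O)NC(=O)C(CC)n1ccnc(NCc2nonc2C)c1=O` gives 0.13 nM under the same conditions. Compound 3 `CCC(C(=O)N[C@@H](CC(=O)O)C(=O)CSCc1ccccc1)n1ccnc(NCC2COc3ccccc3O2)c1=O` gives 30 nM as the highest number of the three, so it is the weakest inhibitor here, beyond the scatter of repeat measurements. Compound 4 `CCC(C(=O)N[C@@H](CC(=O)O)C(=O)CSCc1ccccc1)n1ccnc(NCc2nc(C)no2)c1=O` differs from compound 3 in one place (3-methyl-1,2,4-oxadiazol-5-yl in place of 2,3-dihydro-1,4-benzodioxin-2-yl on a saturated chain carbon bound to a nitrogen on an aromatic ring): 3-methyl-1,2,4-oxadiazol-5-yl stands in place of 2,3-dihydro-1,4-benzodioxin-2-yl on a saturated chain carbon bound to a nitrogen on an aromatic ring. Among the measured compounds shown here, no measured pair shows this change alone, and compound 2 at 0.13 nM differs from compound 3 in more than one place, so it offers only a loose hint toward lower numbers. A modest step toward stronger inhibition is expected (a 2.5-fold lower number from compound 3 to compound 4 (0.40 log units; beyond the scatter)) with wide uncertainty. In this assay compound 4 is estimated at 12 nM with an expected range from 2.5 nM to 50 nM for repeat measurements.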

Compound 4, half-maximal inhibitory concentration: 5.33 nM
Estimate against measurement, compound 4: 2.3-fold (0.35 log units) above; low and high end bracket the measured number.
By their numbers in this assay, from the lowest: compound 2; then compounds 1 and 4 (each within the scatter of the next); then compound 3.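

In this assay, this first pair differing in one place shows that the group on a saturated chain carbon bound to a nitrogen on an aromatic ring affects inhibition: 3-methyl-1,2,4-oxadiazol-5-yl in place of 2,3-dihydro-1,4-benzodioxin-2-yl gives a 5.6-fold lower number from compound 3 to compound 4 (0.75 log units; beyond the scatter). Strong inhibition here therefore does not require the larger group or its six-membered aromatic ring of carbon only. No available evidence explains this step.

Still open, on these data alone, is whether this gain is specific to the oxadiazole ring. A plain phenyl ring or a carboxylic acid in the same place could help separate the effect of the ring from that of the group's size.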